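Replacing (dimethylamino)methyl with 4-(pyridin-2-yl)phenyl

This account rests on a few compounds, and the source may have more. Where it says the series, first, only, none or still open, it means among the compounds named here.

In a functional assay on K562 cells (Homo sapiens) for cytotoxicity, read by fluorescence, with a stated time of 72 h (on this read-out higher numbers stand for weaker inhibition and lower numbers for stronger inhibition), compound 1 `CC(C)c1n[nH]c2c(NCc3ccc(-c4ccccn4)cc3)nc(NCC(C)(C)O)nc12` gives 29 nM and compound 2 `CC(C)c1n[nH]c2c(NCc3ccc(-c4ccccn4)cc3)nc(NCCN(C)C)nc12` gives 125 nM as the higher of the two numbers, so compound 2 is the weaker inhibitor of this pair. For the measured compounds named here, the only measured step is a 4.3-fold higher number from compound 1 to compound 2 (0.63 log units; beyond the scatter) and it is modest, with (dimethylamino)methyl in place of 1-hydroxy-1-methylethyl on a saturated chain carbon bound to a nitrogen on an aromatic ring. Compound 3 `CC(C)c1n[nH]c2c(NCc3ccc(-c4ccccn4)cc3)nc(NCc3ccc(-c4ccccn4)cc3)nc12` alters that same place, with 4-(pyridin-2-yl)phenyl in place of (dimethylamino)methyl on a saturated chain carbon bound to a nitrogen on an aromatic ring as the counted difference. Going by the values given here, no measured compound carries an aromatic ring there, so the one step is only a loose guide. A further rise in the number is expected, with an estimated 2.0-fold higher number from compound 2 to compound 3 (0.30 log units; within the scatter) as the best guess. Compound 3 is estimated at 250 nM with an expected range from 40 nM to 2000 nM as its bounds.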

Compound 3, half-maximal inhibitory concentration: 2540 nM
Beside the measured number, compound 3's estimate is 10-fold (1.01 log units) below it; the whole stated range lies below it.
By their numbers in this assay, from the lowest: compound 1; then compound 2; then compound 3.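

At the saturated chain carbon bound to a nitrogen on an aromatic ring, the two earlier compounds had only shown a modest step between non-aromatic groups, whereas in this assay 4-(pyridin-2-yl)phenyl in place of (dimethylamino)methyl gives a large one, a 20-fold higher number from compound 2 to compound 3 (1.31 log units; beyond the scatter). Set against 1-hydroxy-1-methylethyl, the same group gives an 88-fold higher number from compound 1 to compound 3 (1.94 log units; beyond the scatter), so this position spans a much wider range of numbers than the first pair suggested, and compound 3 is the weakest inhibitor of the three. Nothing available explains why this change has so large an effect.

The compounds shown leave open whether a single ring, such as a plain phenyl, would give a number closer to that of compound 2 or of compound 3. They also leave open how a longer chain ending in a hydroxyl, or a carboxylic acid, would compare with compound 1.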